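This account rests on a few compounds, and the source may have more. Where it says the series, first, only, none or still open, it means among the compounds named here.

Working notes on the series.

The shared core of compound 1 `O=C(CSc1nccn1-c1ccc(Cl)cc1)Nc1ccccc1F` and compound 3 `O=C(CSc1nccn1-c1ccc(Cl)cc1)Nc1ccccc1Br` carries a chloro group; compound 2 `O=C(CSc1nccn1-c1cccc2ccccc12)Nc1ccccc1Br` and the not yet measured compound 4 `O=C(CSc1nccn1-c1cccc2ccccc12)Nc1ccccc1F` share a different core, and the difference between the two cores is not broken down here.

In an ADME assay on MT4 cells (Homo sapiens) for cytotoxicity, read by MTT assay (a higher number here means that more compound is tolerated, a lower number that less compound is tolerated), compound 1 reaches only a limit of the assay, > 345000 nM. Compound 3 likewise reaches only a limit, > 300000 nM. The change between them is fluoro in place of bromo on an aromatic carbon, and the step that the two limits leave unreadable from compound 3 to compound 1 cannot be read in size, because both ends sit at a limit: one at the limit of > 300000 nM in this assay, at which 1 of the 3 values shown sits, and one at the limit of > 345000 nM in this assay, at which 1 of the 3 values shown sits. Going by the values given here, compound 2 is the only member with a number in this assay, where compound 2 gives 30500 nM.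

Among the compounds with values here, the change from compound 2 to compound 4 is fluoro in place of bromo on an aromatic carbon, and it is the same change as the one from compound 3 to compound 1, at the same kind of place. Within the data shown here, since the one measured instance of this change gives no readable size, the expectation for compound 4 rests on the value of compound 2 alone, and the step of a 1.5-fold higher number from compound 2 to compound 4 (0.17 log units; within the scatter) is expected to stay small. Compound 4 is therefore estimated at 45000 nM in this assay, within a range from 15000 nM to 150000 nM.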

Compound 4, half-maximal cytotoxic concentration: 34700 nM
Beside the measured number, compound 4's estimate is 1.3-fold (0.11 log units) above it; the measured number falls inside the stated range.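

In this assay, fluoro in place of bromo on an aromatic carbon gives a 1.1-fold higher number from compound 2 to compound 4 (0.06 log units; within the scatter), so this one readable instance of the change shows no difference beyond the scatter on the core that carries it. On the core carrying the chloro group the same change cannot be read in size, and compound 3 stands there only at a limit: the limit of > 300000 nM in this assay, at which 1 of the 4 values shown sits.

Compound 1 also stands only at a limit, so the single readable step has no readable partner, and the notes neither confirm nor contradict that the size of the change carries from one core to the other: the limit of > 345000 nM in this assay, at which 1 of the 4 values shown sits.

The compounds shown leave open how the number in this assay responds when the 2-bromophenyl or 2-fluorophenyl group carries something other than a halogen, such as an amine or a carboxylic acid. They also leave open whether a longer chain in the part linking the core to the amide would alter the tolerated concentration on either core.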